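Swapping the Chain Amine on a Weak Cytotoxic Compound

A few compounds are considered here, and "the series" means these few. Any claim that something is new, unique, unknown or untested is made for them only; others in the source may bear on it.

Compound 1, `COc1cc2c(Nc3nc4ccc(C(=O)Nc5c(C)cc(C)cc5C)cc4s3)ncnc2cc1OCCCN1CCC(C)CC1`: 7700 nM
Compound 2, `COc1cc2c(Nc3nc4ccc(C(=O)Nc5c(C)cccc5Cl)cc4s3)ncnc2cc1OCCCN1CCCCC1C`: 5300 nM
Compound 3, `CCN(CC)CCCOc1cc2ncnc(Nc3nc4ccc(C(=O)Nc5c(C)cccc5C)cc4s3)c2cc1OC`: 66500 nM

In a functional assay on NCI-H661 cells (Homo sapiens) for cytotoxicity, read by WST assay, with a stated time of 72 h (a lower number here means a stronger inhibitor, a higher number a weaker inhibitor), compound 3 gives the highest of the three numbers, beyond the scatter from both compound 1 and compound 2. Compound 4, `COc1cc2c(Nc3nc4ccc(C(=O)Nc5c(C)cccc5C)cc4s3)ncnc2cc1OCCCN1CCCCC1C`, differs from compound 3 in one place: 2-methylpiperidin-1-yl in place of diethylamino on a saturated chain carbon, three bonds along the chain from an oxygen on an aromatic ring. Among the measured compounds shown here, no measured pair isolates this exact change, but compound 2, which carries the 2-methylpiperidin-1-yl group and differs from compound 4 only in its amide substituents, sits far below compound 3 in this assay. On that basis the author expects compound 4 to move to a clearly lower number, with the step from compound 3 estimated at an 8.3-fold lower number from compound 3 to compound 4 (0.92 log units; beyond the scatter), well beyond the scatter. Compound 4 is therefore estimated at 8000 nM, within a range of 3000 nM to 25000 nM.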

Compound 4, half-maximal inhibitory concentration: 84400 nM
Estimate against measurement, compound 4: 11-fold (1.02 log units) below, outside the stated range (above it).
By their numbers in this assay, from the lowest: compounds 2 and 1 (each within the scatter of the next); then compounds 3 and 4 (each within the scatter of the next).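

In this assay, the change of diethylamino to 2-methylpiperidin-1-yl on the chain can now be read directly, and a 1.3-fold higher number from compound 3 to compound 4 (0.10 log units; within the scatter) leaves the two amines indistinguishable at this position. The large difference comes instead from methyl in place of chloro on an aromatic carbon, with a 16-fold higher number from compound 2 to compound 4 (1.20 log units; beyond the scatter) while the chain amine stays the same. Nothing measured here bears on the reason for either result. From the compounds shown here alone, it remains open whether chloro would bring a similar step alongside diethylamino, and how a morpholine or a longer chain would read at this position.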